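This account rests on a few compounds, and the source may have more. Where it says the series, first, only, none or still open, it means among the compounds named here.

Among the compounds with values here, in an ADME assay on microsomes from liver (Rattus norvegicus) for metabolic stability (a lower number here means that the compound disappears faster, a higher number that the compound lasts longer), compound 2 `COc1cc(OCc2cccc(-c3ccc(OC)nc3)c2)c2cc(-c3cn4nc(OC)sc4n3)oc2c1` gives 0.633 h, the only exact number available so far. The other measured compound, compound 1 `COc1cc(OCc2cccc(-c3ccc(C(F)(F)F)cn3)c2)c2cc(-c3cn4nc(OC)sc4n3)oc2c1`, gives > 2 h, which is a limit of the assay and not a number. Compound 3 `COc1cc(OCc2cccc(-c3ccc(C#N)cn3)c2)c2cc(-c3cn4nc(OC)sc4n3)oc2c1` differs from compound 2 in one group: 5-cyanopyridin-2-yl in place of 6-methoxypyridin-3-yl on an aromatic carbon. Within the data shown here, one measured step bears on this change, an at least 3.1-fold lower number from compound 1 to compound 2 (0.49 log units; beyond the scatter), which lies beyond the scatter and is open-ended. Its 5-cyanopyridin-2-yl group puts compound 3 closer in name to the 5-(trifluoromethyl)pyridin-2-yl of compound 1, so a rise in this assay is expected, undoing much of an at least 3.1-fold lower number from compound 1 to compound 2 (0.49 log units; beyond the scatter), although a nitrile is not a trifluoromethyl and one pair is thin support. The estimated change is a 2.4-fold higher number from compound 2 to compound 3 (0.37 log units; beyond the scatter). For compound 3 the expected half-life is 1.5 h, with an estimated range of 0.7 h to 3.5 h.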

Compound 3, half-life: 0.833 h
Estimate against measurement, compound 3: 1.8-fold (0.26 log units) above; measured number inside the range.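

In this assay, the new step at this aromatic carbon is a 1.3-fold higher number from compound 2 to compound 3 (0.12 log units; within the scatter), which lies within the scatter, so this exchange does not separate 5-cyanopyridin-2-yl from 6-methoxypyridin-3-yl. The other new step, an at least 2.4-fold lower number from compound 1 to compound 3 (0.38 log units; beyond the scatter), lies beyond the scatter and shows that a pyridin-2-yl group alone does not carry the longer half-life of compound 1, since compound 3 has that attachment too and replacing trifluoromethyl with cyano is enough to make the difference. The size of this step remains open-ended because compound 1 stands at a limit of the assay and not at a number: the limit of > 2 h in this assay, at which 1 of the 3 values shown sits.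

Going by these compounds, how far the half-life of compound 1 lies past that limit remains open. So does whether a chlorine atom or a methylsulfonyl group in place of the cyano would side with compound 1 or with compound 3.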